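A few compounds are considered here, and "the series" means these few. Any claim that something is new, unique, unknown or untested is made for them only; others in the source may bear on it.

Measured so far in this series:

compound 1 `O=C(NCCNS(=O)(=O)c1ccc(-c2ccccc2Oc2ccc([N+](=O)[O-])c([N+](=O)[O-])c2)s1)Nc1cc(Cl)cc(Cl)c1` — 2100 nM
compound 2 `COc1ccc(NC(=O)NCCNS(=O)(=O)c2ccc(-c3ccccc3Oc3ccc([N+](=O)[O-])c([N+](=O)[O-])c3)s2)cc1` — 1400 nM
compound 3 `O=C(NCCNS(=O)(=O)c1ccc(-c2ccccc2Oc2ccc([N+](=O)[O-])c([N+](=O)[O-])c2)s1)Nc1ccc([N+](=O)[O-])cc1` — 3000 nM

In a functional assay on RS4-11 cells (Homo sapiens) for inhibition, read by CCK-8 assay, with a stated time of 48 h (a higher number here means a weaker inhibitor, a lower number a stronger inhibitor), compound 3 gives the highest of the three numbers. One of its steps, a 1.4-fold higher number from compound 1 to compound 3 (0.15 log units; within the scatter), stays within the scatter; the other, a 2.1-fold higher number from compound 2 to compound 3 (0.33 log units; beyond the scatter), lies beyond it, though only modestly.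

Compound 4 `COc1cccc(NC(=O)NCCNS(=O)(=O)c2ccc(-c3ccccc3Oc3ccc([N+](=O)[O-])c([N+](=O)[O-])c3)s2)c1` is not yet measured. It differs from compound 3 in one place: 3-methoxyphenyl in place of 4-nitrophenyl on an amide-type nitrogen. The step that bears most directly on this change is a 2.1-fold higher number from compound 2 to compound 3 (0.33 log units; beyond the scatter), since it is the same exchange of nitro and methoxy run in the opposite direction, although the methoxy now sits as 3-methoxyphenyl rather than 4-methoxyphenyl. The other step on this nitrogen, a 1.5-fold lower number from compound 1 to compound 2 (0.18 log units; within the scatter), stayed within the scatter. For the measured compounds named here, no measured pair separates 3-methoxyphenyl from 4-methoxyphenyl, so that part of the change is unconstrained.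

Taken together, a modest lowering of the number is expected, on the order of a 1.8-fold lower number from compound 3 to compound 4 (0.25 log units; within the scatter). Compound 4 is therefore estimated at 1700 nM, with a range from 800 nM to 3600 nM.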

Compound 4, half-maximal inhibitory concentration: 1300 nM
Compound 4: the middle estimate sits 1.3-fold (0.12 log units) above what was measured; measured number inside the range.
By their numbers in this assay, from the lowest: compounds 4, 2, 1 and 3 (each within the scatter of the next, the first and the last beyond it).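

In this assay the replacement of 4-nitrophenyl by 3-methoxyphenyl on the amide-type nitrogen gives a 2.3-fold lower number from compound 3 to compound 4 (0.36 log units; beyond the scatter) and so, with the step from compound 2 to compound 3, gives a second modest separation of a methoxy-bearing phenyl from 4-nitrophenyl. Moving the methoxy gives a 1.1-fold lower number from compound 2 to compound 4 (0.03 log units; within the scatter) and so leaves no readable difference between 3-methoxyphenyl and 4-methoxyphenyl, while 3,5-dichlorophenyl also stays level with 3-methoxyphenyl in a 1.6-fold lower number from compound 1 to compound 4 (0.21 log units; within the scatter) and compound 1 does not separate from compound 3 either, so the separation holds only against the nitro group and not across all aryl groups. No measurement is available to explain these steps.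

On these data alone, all four compounds carry a substituted phenyl on this nitrogen, so the effect of a longer alkyl chain there remains open. The same holds for a phenyl bearing a carboxylic acid or an amine.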